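Bromo in Place of Fluoro: An Expectation for Compound 4

A few compounds are considered here, and "the series" means these few. Any claim that something is new, unique, unknown or untested is made for them only; others in the source may bear on it.

Compound 1, `Fc1ccc(C2=NN(C3=NC(c4ccccc4)CS3)C(c3cccc4ccccc34)C2)cc1`, gives 12400 nM in a functional assay on HeLa cells (Homo sapiens) for inhibition, read by CCK-8 assay, with a stated time of 48 h; a higher number here means a weaker inhibitor, a lower number a stronger inhibitor.
Compound 2, `Cc1ccc(C2=NN(C3=NC(=O)CS3)C(c3ccc4ccccc4c3)C2)cc1`, gives 1760 nM in this assay.
Compound 3, `Fc1ccc(C2=NN(C3=NC(c4ccccc4)CS3)C(c3ccc4ccccc4c3)C2)cc1`, gives 9730 nM in this assay.

Among these three numbers compound 3 stands second highest. Its nearest neighbour is compound 1, and the step of a 1.3-fold lower number from compound 1 to compound 3 (0.11 log units; within the scatter) lies within the scatter, so the two cannot be told apart on these data. Compound 2 sits well away from compound 3, with a lower number that lies beyond the scatter.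

Compound 4, `Brc1ccc(C2=NN(C3=NC(c4ccccc4)CS3)C(c3ccc4ccccc4c3)C2)cc1`, differs from compound 3 by bromo in place of fluoro on an aromatic carbon. Going by the values given here, no measured step bears directly on this change: the only step known, from naphthalen-1-yl to naphthalen-2-yl, touches a different part of the molecule and was small. With nothing pointing in either direction, the expected change in this assay is none beyond the scatter, though a single measurement of this kind may drift either way.

Compound 4 is therefore expected to give about 8000 nM in this assay, with a plausible range from 3000 nM to 25000 nM. This expectation amounts to a 1.2-fold lower number from compound 3 to compound 4 (0.09 log units; within the scatter), a step that is estimated to stay within the usual scatter.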

Compound 4, half-maximal inhibitory concentration: 4960 nM
For compound 4 the middle estimate is 1.6-fold (0.21 log units) above the measured one, and the stated range covers the measured number.
By their numbers in this assay, from the lowest: compound 2; then compounds 4, 3 and 1 (each within the scatter of the next, the first and the last beyond it).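

In this assay, the change from 4-fluorophenyl to 4-bromophenyl, on an aromatic carbon para to a large group, gives a 2.0-fold lower number from compound 3 to compound 4 (0.29 log units; within the scatter) and so stays within the usual scatter of repeated measurements, which means that compound 3 and compound 4 cannot be told apart. Going by these compounds alone, this is the first measured step at this position, as the only earlier step concerned the naphthalenyl group elsewhere in the molecule, and it shows that, for this one pair, exchanging fluoro for bromo produces no change that can be distinguished from the scatter. No accompanying data bear on the reason for this result.

The compounds shown leave open whether a group other than these two halogens at the same position, such as a methoxy group, an amine or a carboxylic acid, would produce a step beyond the scatter. Compound 2 differs from compound 3 and compound 4 in more than one place, so its value cannot be tied to any single change.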